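A few compounds are considered here, and "the series" means these few. Any claim that something is new, unique, unknown or untested is made for them only; others in the source may bear on it.

In a functional assay on UACC-62 cells (Homo sapiens) (on this read-out lower numbers stand for stronger inhibition of growth and higher numbers for weaker inhibition of growth), three compounds sharing one core have been measured. Compound 1 (`O=S(=O)(/C=C/c1ccc(Cl)c(Cl)c1)Cc1ccc(Nc2ncnc3ccccc23)cc1`) gives 21000 nM and compound 3 (`CC(C)(C)c1cc(/C=C/S(=O)(=O)Cc2ccc(Nc3ncnc4ccccc34)cc2)cc(C(C)(C)C)c1O`) gives 6000 nM on this read-out. Compound 2 (`O=S(=O)(/C=C/c1ccc(Br)cc1)Cc1ccc(Nc2ncnc3ccccc23)cc1`) reads > 100000 nM and that is a limit of the assay, not a number. It stands at the limit of > 100000 nM in this assay, at which 1 of the 3 values shown sits, and so offers no exact starting point.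

Compound 4 (`O=S(=O)(/C=C/c1ccc(C(F)(F)F)cc1F)Cc1ccc(Nc2ncnc3ccccc23)cc1`) differs from it in one group, and the change is this: 2-fluoro-4-(trifluoromethyl)phenyl in place of 4-bromophenyl on a double-bonded chain carbon bound to a double-bonded chain carbon with 2-fluoro-4-(trifluoromethyl)phenyl in place of 4-bromophenyl on a double-bonded chain carbon bound to a double-bonded chain carbon.

Among the measured compounds shown here, one measured step touches the same place, namely an at least 4.7-fold higher number from compound 1 to compound 2 (0.67 log units; beyond the scatter) where 4-bromophenyl replaces 3,4-dichlorophenyl. A swap here can therefore move the number beyond the scatter, but that step gives only a lower bound on its size. A move of similar size is expected, toward lower numbers in this assay though compound 4 may also stay at the limit. The expected change is an at least 2.5-fold lower number from compound 2 to compound 4 (0.39 log units; beyond the scatter) and it is only an estimate. The estimated value for compound 4 is 40000 nM with an expected range from 10000 nM to 100000 nM at its upper end.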

Compound 4, concentration for 50% growth inhibition: 100000 nM
For compound 4 the middle estimate is 2.5-fold (0.40 log units) below the measured one; the measured number falls inside the stated range.
By their numbers in this assay, from the lowest: compound 3; then compound 1; then compound 4.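

In this assay, the swap at this place now has a readable size, where the earlier step gave only a bound: 2-fluoro-4-(trifluoromethyl)phenyl in place of 3,4-dichlorophenyl gives a 4.8-fold higher number from compound 1 to compound 4 (0.68 log units; beyond the scatter). So two different replacements of 3,4-dichlorophenyl, the 4-bromophenyl of compound 2 and the group in compound 4, both leave the number higher than that of compound 1. The swap of 4-bromophenyl for 2-fluoro-4-(trifluoromethyl)phenyl gives a number no higher from compound 2 to compound 4 (the limit leaves the size open), and the size of this step cannot be read. Compound 2 carries a limit of the assay, not a number: the limit of > 100000 nM in this assay, at which 1 of the 4 values shown sits.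

Going by these compounds, what stays open is which part of the 2-fluoro-4-(trifluoromethyl)phenyl group, the fluorine or the trifluoromethyl, goes with the higher number. Also open, on these data alone, is how a phenyl ring carrying an amine or a carboxylic acid would read at this place.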